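The source may hold more compounds than are shown below. What is called first, only, known or untested is meant among the compounds shown, and "the series" means these compounds.

Measured so far:
Compound 1 `COc1cc(-c2cc(/C=C/C(=O)c3ccc(N)cc3)[nH]n2)cc(OC)c1OC`: -39%
Compound 2 `COc1ccc(C(=O)/C=C/c2cc(-c3cc(OC)c(OC)c(OC)c3)n[nH]2)cc1OC`: -95%

In a functional assay on PC-3 cells (Homo sapiens) for cytotoxicity, read by sulforhodamine B assay, with a stated time of 48 h, tested at 100 uM (a higher number here means a weaker effect of the compound at the concentration tested, a lower number a stronger effect), compound 2 gives the lowest of the two numbers measured; its nearest neighbour is compound 1, whose value lies higher by a number 56 percentage points lower from compound 1 to compound 2 (beyond the scatter). That single step swapped the ring on the carbonyl carbon, 3,4-dimethoxyphenyl in place of 4-aminophenyl, and was large. Compound 3 `COc1ccc(C(=O)/C=C/c2cc(-c3cc(OC)c(OC)c(OC)c3)n[nH]2)cc1` alters the same ring: hydrogen in place of methoxy on an aromatic carbon. Among the compounds with values here, no measured step removes one methoxy alone, so the direction is uncertain; a change smaller than the step from compound 1 to compound 2 seems likely. Compound 3 is estimated at -75%, between -100% and -40%, a shift of a number 20 percentage points higher from compound 2 to compound 3 (beyond the scatter).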

Compound 3, a percentage reported as activity, at one concentration (the size of the read-out at that concentration, not a potency): 1%
Beside the measured number, compound 3's estimate is 76 percentage points below it, outside the stated range (above it).
By their numbers in this assay, from the lowest: compound 2; then compound 1; then compound 3.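

In this assay, taking one methoxy off the 3,4-dimethoxyphenyl ring leaves 4-methoxyphenyl and sharply weakens the effect, with a number 96 percentage points higher from compound 2 to compound 3 (beyond the scatter), so this single group matters a great deal. Methoxy is also not interchangeable with amino on the remaining ring, with a number 40 percentage points higher from compound 1 to compound 3 (beyond the scatter), which means the 4-aminophenyl ring gives the stronger effect of the two. Nothing available explains either step.

On these data alone, whether this carbon needs a methoxy specifically or simply any group remains open. A hydroxyl, a fluorine or an ethoxy there would help separate these possibilities.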